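The source may report more compounds than this note shows. Statements on the series, on what has been measured and on what is new or still open speak of the compounds shown alone.

Measured compounds:
- Compound 1 `N#Cc1ccc2nc(-c3ccc(-c4ccccc4F)cc3)[nH]c2c1`: > 20000 nM
- Compound 2 `NS(=O)(=O)c1ccc2nc(-c3ccc(-c4ccccc4F)cc3)[nH]c2c1`: > 20000 nM

In an assay on isolated protein for inhibition of stearoyl-CoA desaturase 5 (Homo sapiens) (on this read-out lower numbers stand for stronger inhibition and higher numbers for weaker inhibition), compound 1 gives > 20000 nM, a limit of the assay rather than a number. In this assay compound 2 gives > 20000 nM, likewise only a limit. The step that the two limits leave unreadable from compound 1 to compound 2 therefore cannot be read. Compound 2 thus stands only at the limit (the limit of > 20000 nM in this assay, at which 2 of the 2 values shown sit), with no measured number of its own.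

Compound 3 `CCS(=O)(=O)c1ccc2nc(-c3ccc(-c4ccccc4F)cc3)[nH]c2c1` differs from compound 2 by ethyl in place of amino on a sulfonyl sulfur. Within the data shown here, the single measured step, a step that the two limits leave unreadable from compound 1 to compound 2, is unreadable and so gives no guidance for this change. Compound 3 is expected to give 30000 nM in this assay, with a range from 6000 nM to 150000 nM. The expected step that the limit leaves unreadable from compound 2 to compound 3 is an estimate only, since the starting point is a limit.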

Compound 3, half-maximal inhibitory concentration: > 20000 nM
Compound 3: only a limit was reported; the forecaster's own chance of this, stated with the estimate: 70%; the middle value does not contradict the limit.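

Among these compounds, no step among compound 1, compound 2 and compound 3 can be read, since each value is only a limit: the limit of > 20000 nM in this assay, at which 3 of the 3 values shown sit. As far as these compounds go, it remains open whether any group at this place on the shared core gives a measurable value in this assay.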